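The source may report more compounds than this note shows. Statements on the series, on what has been measured and on what is new or still open speak of the compounds shown alone.

In a physicochemical assay for solubility, with a stated time of 18 h, at pH 7.4 (on this read-out lower numbers stand for lower solubility and higher numbers for higher solubility), the measured compounds read as follows:

Compound 1 `FC(F)(F)c1ccc(-c2ccc3c(NCCCNCc4ccco4)ccnc3c2)cc1` gives 32000 nM
Compound 2 `COc1cccc(Oc2ccc3c(NCCCNCc4ccco4)ccnc3c2)c1` gives 14500 nM
Compound 3 `COc1cccc(Oc2ccc3c(NCCCNCc4cccc(OC)c4O)ccnc3c2)c1` gives 14500 nM

Compound 2 stands level with compound 3, and the two share the lowest number of the three. Compound 4 `CC(C)CCc1ccc2c(NCCCNCc3ccco3)ccnc2c1` carries isopentyl in place of 3-methoxyphenoxy on an aromatic carbon and is still unmeasured. The swap at this same carbon gave a modest step (a 2.2-fold lower number from compound 1 to compound 2 (0.34 log units; beyond the scatter)), while the change on the chain gave none beyond the scatter (no change at the digits printed from compound 2 to compound 3 (within the scatter)). Among the measured compounds shown here, no measured compound has a group without a ring at this carbon, so the guide is thin. In this assay the expected step is small (a 1.7-fold higher number from compound 2 to compound 4 (0.22 log units; within the scatter)), with a higher number more likely than a lower one. For compound 4 the estimated value is 24000 nM (expected range 10000 nM to 50000 nM).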

Compound 4, solubility: 4200 nM
For compound 4 the middle estimate is 5.7-fold (0.76 log units) above the measured one, outside the stated range (below it).
By their numbers in this assay, from the lowest: compound 4; then compounds 2 and 3 (each within the scatter of the next); then compound 1.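

In this assay, swapping a ring-bearing group at this aromatic carbon for isopentyl, which has no ring, lowers the number from both ring-bearing compounds that differ only here (a 3.5-fold lower number from compound 2 to compound 4 (0.54 log units; beyond the scatter); a 7.6-fold lower number from compound 1 to compound 4 (0.88 log units; beyond the scatter)). This carbon therefore tolerates larger shifts than the earlier step between two ring-bearing groups showed. No measurement here explains why the number falls.

The compounds shown leave open whether a shorter chain such as ethyl, or an amine at this carbon, would read like isopentyl. They also leave open whether the same drop holds with 2-hydroxy-3-methoxyphenyl in place of furan-2-yl on the chain.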